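This account rests on a few compounds, and the source may have more. Where it says the series, first, only, none or still open, it means among the compounds named here.

In a functional assay on HeLa cells (Homo sapiens) for antiproliferative activity, read by MTT assay, with a stated time of 72 h (on this read-out higher numbers stand for weaker inhibition and lower numbers for stronger inhibition), compound 1 `O=c1[nH]c(=O)n(CCC(CO)CO)cc1-c1ccco1` is recorded at > 100000 nM, which is a limit of the measurement and not a number. Compound 2 `CC(=O)OCC(CCn1cc(C#Cc2cc(F)cc(F)c2)c(=O)n(C(=O)c2ccccc2)c1=O)COC(C)=O` gives 64500 nM in this assay, the only real number among the two results shown, the other sitting at the limit of > 100000 nM in this assay, at which 1 of the 2 values shown sits. Compound 3 `CCCCCc1ccc(C#Cc2cn(CCC(COC(C)=O)COC(C)=O)c(=O)n(C(=O)c3ccccc3)c2=O)cc1` differs from compound 2 in one place: 4-pentylphenyl in place of 3,5-difluorophenyl on a triple-bonded carbon. For the measured compounds named here, no measured pair covers such a change, so the step from compound 2 to compound 3 is expected to be small, toward stronger inhibition, at a 1.6-fold lower number from compound 2 to compound 3 (0.21 log units; within the scatter). Compound 3 is therefore estimated at 40000 nM, with a range from 10000 nM to 150000 nM.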

Compound 3, half-maximal inhibitory concentration: 79100 nM
Compound 3: the middle estimate sits 2.0-fold (0.30 log units) below what was measured; the range from low to high includes it.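

Placing 4-pentylphenyl instead of 3,5-difluorophenyl on the triple-bonded carbon gives a 1.2-fold higher number from compound 2 to compound 3 (0.09 log units; within the scatter) in this assay. For this pair, then, losing both fluorines and adding a pentyl chain leaves the read-out unchanged beyond the scatter. Nothing measured here explains why the swap has so little effect. Going by these compounds, whether an amine or a carboxylic acid on the phenyl ring would move the number remains open. So does whether a longer chain than pentyl would give stronger inhibition.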